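The source may hold more compounds than are shown below. What is called first, only, known or untested is meant among the compounds shown, and "the series" means these compounds.

Measured so far:
compound 1 (`O=C(CC(c1ccccc1)C(C(=O)Nc1ccccn1)C(=O)Nc1ccccn1)c1ccccc1`): "not active" (no number reported)
compound 2 (`O=C(CC(c1ccc(F)cc1)C(C(=O)Nc1ccccn1)C(=O)Nc1ccccn1)c1ccccc1`): 20900 nM
compound 3 (`O=C(CC(c1ccccc1)C(C(=O)Nc1ccccn1)C(=O)Nc1ccccn1)c1ccc(F)cc1`): "not active" (no number reported)

The starting point here offers no figure to work from. In a functional assay on MCF7 cells (Homo sapiens) for inhibition, read by MTT assay, with a stated time of 48 h (on this read-out lower numbers stand for stronger inhibition and higher numbers for weaker inhibition), compound 3 is reported only as inactive ("not active" (no number reported)), so it has no single number. Compound 1 received the same verdict ("not active" (no number reported)). Only compound 2 reaches a measured concentration (20900 nM), and a number this high stands for weak inhibition.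

The compound still to be measured is compound 4 (`O=C(CC(c1ccc(Cl)cc1)C(C(=O)Nc1ccccn1)C(=O)Nc1ccccn1)c1ccc(F)cc1`). The change is chloro in place of hydrogen on an aromatic carbon and amounts to phenyl to 4-chlorophenyl, with chloro in place of hydrogen on an aromatic carbon. Going by the values given here, no measured pair in this small set shows a change of this kind, so the size of the step in this assay cannot be read directly from the data. A modest step towards stronger inhibition is expected at best, and a second report of no activity remains quite possible. Any number that does appear is expected to lie in the same weak region as compound 2 (20900 nM), the only measured anchor available. Compound 4 is estimated at 20000 nM with an expected range from 7000 nM to 60000 nM in this read-out.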

Compound 4, half-maximal inhibitory concentration: 21200 nM
The estimate for compound 4 lay 1.1-fold (0.03 log units) below the measured number, and the stated range covers the measured number.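

No step can be read from compound 3 to compound 4, as compound 3 has no number in this assay and only compound 4 gives a value, 21200 nM. The compounds shown leave open how much phenyl to 4-chlorophenyl alone shifts inhibition. No measurement here offers an explanation for this result.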